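The source may hold more compounds than are shown below. What is called first, only, known or untested is meant among the compounds shown, and "the series" means these compounds.

Compound 1 `CO/C(O)=C1\C(C)=NC(C)=C([N+](=O)[O-])C1c1ccncc1` was tested in a functional assay (cardiac atrium) for agonist activity, with Cavia porcellus as the target (a lower number here means that less compound is needed, a higher number that more compound is needed for the effect), where compound 1 gives 48500 nM. Compound 2 `CC1=NC(C)=C([N+](=O)[O-])C(c2ccncc2)/C1=C(\O)OC(C)(C)C` differs from it by a single change, (tert-butyl in place of methyl on an oxygen on an unsaturated carbon), and in this assay compound 2 gives 2820 nM. The step between them is a 17-fold lower number from compound 1 to compound 2 (1.24 log units; beyond the scatter). Compound 3 `CO/C(O)=C1\C(C)=NC(C)=C([N+](=O)[O-])C1c1cccnc1` carries a different change on the core of compound 1, namely (pyridin-3-yl in place of pyridin-4-yl on a saturated ring carbon). In this assay compound 3 gives 70000 nM, and the step is a 1.4-fold higher number from compound 1 to compound 3 (0.16 log units; within the scatter). Among the compounds with values here, compound 2 and compound 3 differ in two places, and their values show only that compound 2 has the lower number.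

Compound 4 `CC1=NC(C)=C([N+](=O)[O-])C(c2cccnc2)/C1=C(\O)OC(C)(C)C` has not yet been measured. It is related to compound 3 by tert-butyl in place of methyl on an oxygen on an unsaturated carbon, which is the same change that leads from compound 1 to compound 2, at a place whose surroundings read the same in both pairs. The two cores differ by pyridin-3-yl in place of pyridin-4-yl on a saturated ring carbon. The step from compound 3 to compound 4 is expected to be a 16-fold lower number from compound 3 to compound 4 (1.19 log units; beyond the scatter). This expectation stands beside a 17-fold lower number from compound 1 to compound 2 (1.24 log units; beyond the scatter) and rests on the cores behaving alike in this assay, because a 1.4-fold higher number from compound 1 to compound 3 (0.16 log units; within the scatter) is within the scatter. Within the data shown here, only one measured pair supports the transfer, so the range is kept wide. Compound 4 is therefore estimated at 4500 nM, with a range from 1500 nM to 14000 nM.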

Compound 4, half-maximal effective concentration: 14600 nM
Compound 4: middle estimate off by 3.2-fold (0.51 log units), on the low side; measured number outside the range, above it.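

In this assay, tert-butyl in place of methyl on the oxygen lowers the number on both cores, with a 4.8-fold lower number from compound 3 to compound 4 (0.68 log units; beyond the scatter), so the direction of the step carries over from the core of compound 1 while its size does not: the same change on two cores in this assay, a 17-fold lower number (1.24 log units; beyond the scatter) from compound 1 to compound 2 and a 4.8-fold lower number (0.68 log units; beyond the scatter) from compound 3 to compound 4, 3.6-fold (0.55 log units) apart, beyond the scatter of two such steps Read from the other side, pyridin-3-yl in place of pyridin-4-yl on the saturated ring carbon gives a 5.2-fold higher number from compound 2 to compound 4 (0.71 log units; beyond the scatter), whereas the same change with methyl on the oxygen stayed within the scatter, so the two changes do not simply add up in this series: the same change on two cores in this assay, a 1.4-fold higher number (0.16 log units; within the scatter) from compound 1 to compound 3 and a 5.2-fold higher number (0.71 log units; beyond the scatter) from compound 2 to compound 4, 3.6-fold (0.55 log units) apart, beyond the scatter of two such steps This shows that the size of the step on one core could not be taken over unchanged to the other, but it rests on a single set of four compounds and does not show why the steps differ or how the change would behave on any further core.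

The compounds shown leave open whether ethyl or isopropyl on that oxygen would lower the number on both cores as tert-butyl does, and whether a longer chain there would continue the trend. They also leave open how phenyl on the saturated ring carbon would combine with either group on the oxygen.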